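A few compounds are considered here, and "the series" means these few. Any claim that something is new, unique, unknown or untested is made for them only; others in the source may bear on it.

Measured compounds:
compound 1 `CC(C)n1nc(C(=O)N[C@H]2COc3ccccc3N(C)C2=S)nc1Cc1ccccc1` – 360 nM
compound 2 `CC(C)CCn1nc(C(=O)N[C@H]2COc3ccccc3N(C)C2=S)nc1Cc1ccccc1` – 3640 nM

Going by the values given here, of the two numbers obtained in a functional assay on HT-29 cells (Homo sapiens) for inhibition, read by luminescence and CellTiter-Glo, with a stated time of 24 h (on this read-out lower numbers stand for an effect already at smaller amounts and higher numbers for an effect only at larger amounts of compound), compound 2 stands highest; its nearest neighbour is compound 1, and the one measured step between them, a 10-fold higher number from compound 1 to compound 2 (1.00 log units; beyond the scatter), came from an isopentyl in place of an isopropyl on an aromatic nitrogen.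

Compound 3 `CN1C(=S)[C@@H](NC(=O)c2nc(Cc3ccccc3)n(CC3CCOC3)n2)COc2ccccc21` has not yet been measured. It differs from compound 2 by oxolan-3-yl in place of isobutyl on a saturated chain carbon bound to an aromatic nitrogen. Among the compounds with values here, the single measured step bears on this change only loosely: it showed that enlarging the chain on the aromatic nitrogen raised the number, whereas here the chain keeps its length and its outer part becomes a five-membered ring with one oxygen. Within the data shown here, no measured pair probes a ring at this place, so the direction is uncertain, and the expected step is small. The expected step is therefore a 1.5-fold lower number from compound 2 to compound 3 (0.16 log units; within the scatter). Compound 3 is thus estimated to give about 2500 nM in this assay, with a range from 600 nM to 10000 nM.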

Compound 3, half-maximal effective concentration: 4420 nM
Beside the measured number, compound 3's estimate is 1.8-fold (0.25 log units) below it, within the range that was stated.
By their numbers in this assay, from the lowest: compound 1; then compounds 2 and 3 (each within the scatter of the next).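

In this assay the step of a 1.2-fold higher number from compound 2 to compound 3 (0.08 log units; within the scatter) shows that, on a saturated chain carbon bound to an aromatic nitrogen, oxolan-3-yl cannot be told apart from isobutyl, although it brings a five-membered non-aromatic ring and a hydrogen-bond acceptor that isobutyl lacks. Measured against isopropyl on the aromatic nitrogen, (oxolan-3-yl)methyl gives a 12-fold higher number from compound 1 to compound 3 (1.09 log units; beyond the scatter) and so falls on the same side of the gap as isopentyl, which gave a 10-fold higher number from compound 1 to compound 2 (1.00 log units; beyond the scatter) in the same comparison. Among these three compounds, isopropyl alone stands apart from the two other groups, with or without the ring and its oxygen, and nothing at hand accounts for this.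

The compounds shown leave open whether a methyl group or a cyclopropyl ring on the aromatic nitrogen would give a number lower still than that of compound 1, so the low end of this position remains unmapped. They also leave open whether a primary amine or a carboxylic acid at the end of the chain would separate from isopentyl where the ring oxygen of oxolan-3-yl did not.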